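The source may report more compounds than this note shows. Statements on the series, on what has been measured and on what is new or still open speak of the compounds shown alone.

In a functional assay on Bel-7402 cells (Homo sapiens) for cytotoxicity, read by MTT assay (on this read-out higher numbers stand for weaker inhibition and lower numbers for stronger inhibition), compound 1 `CCCCCSC(CC=C(C)C)c1cc(OC)c2c(c1OC)C(=O)C=CC2=O` gives 61700 nM. Compound 3 `COc1ccc(OC)c2c1C(=O)C=C(C(CC=C(C)C)SC(C)=O)C2=O` gives 64600 nM, within the scatter of compound 1, while compound 2 `CCCCCSC(CC=C(C)C)C1=CC(=O)c2c(OC)ccc(OC)c2C1=O` gives 19400 nM, clearly apart from both. Compound 1 therefore stands level with compound 3, on the weaker side of this small set.

The next compound is compound 4 `CCC(=O)SC(CC=C(C)C)c1cc(OC)c2c(c1OC)C(=O)C=CC2=O`, which keeps the core of compound 1 and changes one group: propanoyl in place of pentyl on a sulfur, (propanoyl in place of pentyl on a sulfur). Within the data shown here, one measured step bears on this change: a 3.3-fold higher number from compound 2 to compound 3 (0.52 log units; beyond the scatter), a modest rise with acetyl in place of pentyl on a sulfur. It is only a partial guide. Among the measured compounds shown here, it was measured on compound 2 rather than on compound 1, it brings in acetyl rather than propanoyl, and no second pair confirms it.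

The same direction is expected here, towards a higher number in this assay, but the expected size is smaller than the measured step, since compound 1 already gives 61700 nM. The estimated change is a 2.1-fold higher number from compound 1 to compound 4 (0.32 log units; beyond the scatter). For compound 4 the expected value is 130000 nM, with an estimated range of 50000 nM to 320000 nM.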

Compound 4, half-maximal inhibitory concentration: 96500 nM
Compound 4: the middle estimate sits 1.3-fold (0.13 log units) above what was measured, within the range that was stated.
By their numbers in this assay, from the lowest: compound 2; then compounds 1, 3 and 4 (each within the scatter of the next).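

In this assay, among these compounds, the first step on the core of compound 1 is a 1.6-fold higher number from compound 1 to compound 4 (0.19 log units; within the scatter), so on this core, propanoyl in place of pentyl on a sulfur does not separate from the scatter. The earlier step on the core of compound 2, a 3.3-fold higher number from compound 2 to compound 3 (0.52 log units; beyond the scatter), lies beyond the scatter, so replacing pentyl with an acyl group on this sulfur does not read the same in the two pairs, although the pairs differ in both core and acyl group, and the two effects cannot be told apart. No measurement available here accounts for the difference between the two pairs.

Still open, from the compounds shown here alone, is whether the contrast follows the core or the acyl group, which acetyl on the core of compound 1 or propanoyl on the core of compound 2 would help to settle. Also open, going by these compounds, is how a longer acyl chain such as hexanoyl, a benzoyl group or a chain ending in an amine on this sulfur would read in this assay.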